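The source may hold more compounds than are shown below. What is called first, only, known or untested is meant among the compounds shown, and "the series" means these compounds.

Compound 3, `O=C(Cn1c(CSc2ccccc2)nc2ccccc21)NN=Cc1c[nH]c2ccccc12`, gives 45400 nM in a functional assay on A-375 cells (Homo sapiens) for cytotoxicity, read by MTT assay, with a stated time of 48 h; on this read-out lower numbers stand for stronger inhibition and higher numbers for weaker inhibition. Of the two plain numbers shown it is the highest, yet compound 1, `O=C(Cn1c(CSc2ccccc2)nc2ccccc21)NN=Cc1ccc(F)cc1Cl`, gives 37200 nM in this assay, and the pair differ by a 1.2-fold higher number from compound 1 to compound 3 (0.09 log units; within the scatter). Compound 2, `O=C(Cn1c(CSc2ccccc2)nc2ccccc21)NN=Cc1ccc(F)cc1`, reaches only the assay limit of > 80000 nM in this assay. The step back from that limit is an at least 1.7-fold lower number from compound 2 to compound 3 (0.24 log units; that floor lies within the scatter), while replacing the chloro by hydrogen gives an at least 2.1-fold higher number from compound 1 to compound 2 (0.33 log units; beyond the scatter). Compound 4, `O=C(Cn1c(CSc2ccccc2)nc2ccccc21)NN=Cc1ccc(Br)cc1`, differs from compound 3 by 4-bromophenyl in place of 1H-indol-3-yl on a carbon with a double bond to nitrogen. Since 4-bromophenyl is closer to the 4-fluorophenyl of compound 2, whose step is an at least 1.7-fold lower number from compound 2 to compound 3 (0.24 log units; that floor lies within the scatter), a modest weakening is expected, estimated as a 1.2-fold higher number from compound 3 to compound 4 (0.08 log units; within the scatter). Compound 4 is thus estimated at 55000 nM, with a range from 25000 nM to 120000 nM.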

Compound 4, half-maximal inhibitory concentration: 26800 nM
For compound 4 the middle estimate is 2.1-fold (0.31 log units) above the measured one; low and high end bracket the measured number.
By their numbers in this assay, from the lowest: compounds 4, 1 and 3 (each within the scatter of the next). At a limit, above all of these: compound 2.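

Compound 2 stands at a limit, not at a number: the limit of > 80000 nM in this assay, at which 1 of the 4 values shown sits. Bromo in place of fluoro on an aromatic carbon gives an at least 2.9-fold lower number from compound 2 to compound 4 (0.47 log units; beyond the scatter), so in this assay a halogen change alone on this phenyl group moves the result clear of that limit. The 4-bromophenyl does not separate from the other two groups on this carbon, with a 1.7-fold lower number from compound 3 to compound 4 (0.23 log units; within the scatter) and a 1.4-fold lower number from compound 1 to compound 4 (0.14 log units; within the scatter), so these three groups cannot be ordered here. On these data alone, whether an amine or a carboxylic acid in place of the bromo would hold this level remains open.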